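The source may report more compounds than this note shows. Statements on the series, on what has been measured and on what is new or still open speak of the compounds shown alone.

Measured so far in a functional assay on HL-60 cells (Homo sapiens) for antiproliferative activity, read by MTT assay; a lower number here means a stronger inhibitor, a higher number a weaker inhibitor:
- compound 1, `C=CC[C@@H]1O[C@H](COCc2ccccc2)[C@@H](OCc2ccccc2)[C@H](OCc2ccccc2)[C@H]1O`: compound 1 gives 15100 nM
- compound 2, `OC[C@H]1O[C@@H](Cc2ccccc2)[C@H](O)[C@@H](OCc2ccccc2)[C@@H]1OCc1ccccc1`: compound 2 gives 20200 nM
- compound 3, `CC(C)C[C@@H]1O[C@H](COCc2ccccc2)[C@H](OCc2ccccc2)[C@H](OCc2ccccc2)[C@H]1O`: compound 3 gives "not active" (no number reported), with no number

Among the measured compounds shown here, compound 3 therefore has no place on the scale set by compound 1 and compound 2; the only statement made of compound 3 in this assay is that no activity was found, and the two numbered compounds both sit in the weak range.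

The step to compound 4, `CC(C)C[C@@H]1O[C@H](COCc2ccccc2)[C@@H](OCc2ccccc2)[C@H](OCc2ccccc2)[C@H]1O`, is described as the two compounds have the same atoms and bonds and differ only in configuration as drawn: 1 of 5 stereo elements differ; a stereocentre at a saturated ring carbon is drawn S in compound 3 and R in compound 4. For the measured compounds named here, no measured pair of neighbours shows how such a change plays out in this assay, so the size of the step cannot be read from the series. Compound 1 carries the same configuration at that centre as compound 4 and shows measurable but weak inhibition, whereas compound 3 shows none; the expectation is that compound 4 returns to the weak, measurable range rather than staying unreported, with considerable uncertainty in both directions.

Compound 4 is estimated in this assay at 18000 nM, with a range of 5000 nM to 60000 nM.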

Compound 4, half-maximal inhibitory concentration: 8500 nM
The estimate for compound 4 lay 2.1-fold (0.33 log units) above the measured number; measured number inside the range.
By their numbers in this assay, from the lowest: compounds 4, 1 and 2 (each within the scatter of the next, the first and the last beyond it).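

In this assay compound 3 is reported as not active, whereas compound 4 gives 8500 nM, so at this saturated ring carbon the configuration separates a measurable number from no number at all. This contrast rests on a single stereocentre, drawn S in compound 3 and R in compound 4, and the ground for tying it to that centre is: the fact that compounds 3 and 4 differ only in the configuration as drawn. With the R configuration kept, isopropyl in place of vinyl on the saturated chain carbon leaves the two compounds unseparated, with a 1.8-fold lower number from compound 1 to compound 4 (0.25 log units; within the scatter), so this change does not move the series out of the weak range in this assay.

On these data alone, this stereocentre result comes from one pair, and it remains open whether the S configuration also removes the measurable number with vinyl in place of isopropyl. Also open, as far as these compounds go, is how far the chain tolerates change with the R configuration, for example whether an amine, a carboxylic acid or a longer chain at this place would keep, improve or lose the weak activity seen for compound 1 and compound 4.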